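Sulfonamide in place of thioether on an octadecyloxy acetamide

The source may hold more compounds than are shown below. What is called first, only, known or untested is meant among the compounds shown, and "the series" means these compounds.

Compounds measured so far:
compound 1, `CCCCCCCCCCCCCCCCCCOCC(CCCO)NC(C)=O` — > 200000 nM
compound 2, `CCCCCCCCCCCCCCCCCCOCC(CCSc1ccc(C)cc1)NC(C)=O` — > 200000 nM

In an assay for inhibition of putative inactive group IIC secretory phospholipase A2 (Homo sapiens) (on this read-out lower numbers stand for stronger inhibition and higher numbers for weaker inhibition), compound 1 reaches only a limit of the assay, > 200000 nM. In this assay compound 2 likewise reaches only a limit, > 200000 nM. Going by the values given here, the one step measured, a step that the two limits leave unreadable from compound 1 to compound 2, is therefore not readable in size, and the limit of > 200000 nM in this assay, at which 2 of the 2 values shown sit, describes where both values sit.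

Compound 3, `CCCCCCCCCCCCCCCCCCOCC(CNS(=O)(=O)c1ccc(C)cc1)NC(C)=O`, is not yet measured. It differs from compound 2 in one place: ((4-methylphenyl)sulfonyl)amino in place of ((4-methylphenyl)sulfanyl)methyl on a saturated chain carbon, two bonds along the chain from an amide-type nitrogen. Among the compounds with values here, no measured step bears on this change, and the single step between compound 1 and compound 2 gives no readable size. The expectation for compound 3 is therefore that in this assay it too stays near the limit, with an estimated step that the limit leaves unreadable from compound 2 to compound 3. The estimate for compound 3 in this assay is 300000 nM, expected between 100000 nM and 1000000 nM.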

Compound 3, half-maximal inhibitory concentration: > 200000 nM
Compound 3 was reported as a limit; the forecaster's own chance of this, stated with the estimate: 85%; the middle value does not contradict the limit.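

In this assay, going by these compounds alone, compound 3 is reported only as a limit (> 200000 nM), so no step among compound 1, compound 2 and compound 3 can be read: the limit of > 200000 nM in this assay, at which 3 of the 3 values shown sit. The compounds shown leave open whether any change to the shared core gives a readable value in this assay at all.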